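Working notes: the step from compound 2 to compound 3

The source may hold more compounds than are shown below. What is called first, only, known or untested is meant among the compounds shown, and "the series" means these compounds.

Measured in an ADME assay on tissue (MDA-MB-231 cells, Homo sapiens) for pharmacokinetics; a higher number here means that the compound lasts longer, a lower number that the compound disappears faster:
- compound 1 `N[C@@H](CC(=O)OC[C@H]1O[C@@H](n2cc(F)c(=O)[nH]c2=O)C[C@@H]1OC(=O)C[C@H](N)C(=O)O)C(=O)O`: 0.155 h
- compound 2 `N[C@@H](CCC(=O)O[C@H]1C[C@H](n2cc(F)c(=O)[nH]c2=O)O[C@@H]1CO)C(=O)O`: 0.138 h

In this assay compound 1 at 0.155 h and compound 2 at 0.138 h lie within the usual scatter of each other, so neither can be ranked above the other. Compound 3 `N[C@@H](CC(=O)O[C@H]1C[C@H](n2cc(F)c(=O)[nH]c2=O)O[C@@H]1CO)C(=O)O` has not yet been measured. It carries amino(carboxy)methyl in place of 2-amino-2-carboxyethyl on a saturated chain carbon bound to a carbonyl carbon. Among the compounds with values here, no two measured compounds differ in one place, so the series offers no direct precedent for the size or direction of this change. Within the data shown here, the only guide is the narrow range of the two values in hand, with compound 2 at 0.138 h as the starting point. No change beyond the scatter is expected, and neither direction is favoured. The expected step is a 1.0-fold higher number from compound 2 to compound 3 (0.01 log units; within the scatter), which would stay within the scatter. For compound 3 the estimate is 0.14 h, with an expected range of 0.09 h to 0.22 h.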

Compound 3, half-life: 0.322 h
Beside the measured number, compound 3's estimate is 2.3-fold (0.36 log units) below it; the measured number lies above the stated range.
By their numbers in this assay, from the lowest: compounds 2 and 1 (each within the scatter of the next); then compound 3.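

In this assay, within the data shown here, amino(carboxy)methyl in place of 2-amino-2-carboxyethyl on a saturated chain carbon bound to a carbonyl carbon gives a 2.3-fold higher number from compound 2 to compound 3 (0.37 log units; beyond the scatter), the first reading of a change at one place, and it shows that the read-out is not indifferent to the length of this chain. Hydrogen in place of (2-amino-2-carboxyethyl)carbonyl on an oxygen on a saturated carbon gives a 2.1-fold higher number from compound 1 to compound 3 (0.32 log units; beyond the scatter), so compound 3 stands clear of both earlier compounds, although the two steps start from different structures and change different places. Nothing measured on these compounds accounts for either step.

The compounds shown leave open whether the step from 2-amino-2-carboxyethyl to amino(carboxy)methyl depends on the amine, on the carboxylic acid or on the chain alone, a question that a plain acetyl group, carrying neither the amine nor the carboxylic acid, would begin to separate from the other two. They also leave open whether the same step would hold with an amide in place of the ester, or with the opposite configuration at the defined stereocentre of the amino(carboxy)methyl group.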